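Nitropyrimidine ester series: swapping benzyl for ester-bearing chain

This account rests on a few compounds, and the source may have more. Where it says the series, first, only, none or still open, it means among the compounds named here.

Measured compounds in a functional assay on HepG2 cells (Homo sapiens) for antiproliferative activity, read by MTT assay, with a stated time of 48 h; on this read-out higher numbers stand for weaker inhibition and lower numbers for stronger inhibition:
compound 1 `CCOC(=O)CN(Cc1ccccc1)c1nc(NCc2ccccc2)ncc1[N+](=O)[O-]` gives 21000 nM
compound 2 `COC(=O)CN(C)c1nc(Nc2ccc(Cl)cc2)ncc1[N+](=O)[O-]` gives 49800 nM
compound 3 `CCOC(=O)CNc1nc(NCc2ccccc2)ncc1[N+](=O)[O-]` gives > 100000 nM

Compound 1 gives the lowest of the two numbers in this assay; the nearest is compound 2, a step beyond the scatter. The value of compound 3 is a limit of this assay, not a number (the limit of > 100000 nM in this assay, at which 1 of the 3 values shown sits).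

Compound 4 `CCOC(=O)CNc1ncc([N+](=O)[O-])c(N(CC(=O)OCC)Cc2ccccc2)n1` differs from compound 1 in one place: ethoxycarbonyl in place of phenyl on a saturated chain carbon bound to a nitrogen on an aromatic ring. The shared core and the nitro group stay as they are.

Among the measured compounds shown here, only one step among the measured compounds touches a benzyl group: an at least 4.7-fold higher number from compound 1 to compound 3 (0.67 log units; beyond the scatter). That change sits on the other nitrogen of the core and removes the benzyl outright, so it bears on compound 4 only loosely. For the measured compounds named here, compound 2 carries a ring directly on the nitrogen and a methyl on the other nitrogen, and its number is higher than that of compound 1; no single-place step connects it to compound 4. A higher number for compound 4 is therefore expected, of modest size, a 2.1-fold higher number from compound 1 to compound 4 (0.33 log units; beyond the scatter). Compound 4 is estimated at 45000 nM, with a range from 18000 nM to 100000 nM.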

Compound 4, half-maximal inhibitory concentration: 44500 nM
Beside the measured number, compound 4's estimate is 1.0-fold (0.00 log units) above it; measured number inside the range.
By their numbers in this assay, from the lowest: compound 1; then compounds 4 and 2 (each within the scatter of the next). At a limit, above all of these: compound 3.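

Among the compounds shown here, this is the one step that leaves the nitrogen substituted and changes only what the chain carries: in this assay ethoxycarbonyl in place of phenyl gives a 2.1-fold higher number from compound 1 to compound 4 (0.33 log units; beyond the scatter). An aromatic ring at this place is thus not required for a measured number, since the ((ethoxycarbonyl)methyl)amino group of compound 4 still gives a value short of the assay's limit. No measurement shown gives a cause for this step.

From the compounds shown here alone, whether the ester itself counts stays open, and a carboxylic acid, a primary amide or a longer chain at the same place would test that. Also open, going by these compounds, is how a phenyl carrying a chlorine on the same chain would compare with the benzylamino group of compound 1.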